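Chloro in Place of Methyl in Compound 2

The source may hold more compounds than are shown below. What is called first, only, known or untested is meant among the compounds shown, and "the series" means these compounds.

Compound 1 `Cc1ccsc1-c1cc(-c2ccco2)cc(-c2ccc(Cl)cc2)n1`: 710 nM
Compound 2 `Cc1ccccc1-c1cc(-c2ccoc2)cc(-c2ccc(Cl)s2)n1`: 990 nM

In a functional assay on HCT-15 cells (Homo sapiens) for cytotoxicity, read by ELISA, with a stated time of 4 days (on this read-out lower numbers stand for stronger inhibition and higher numbers for weaker inhibition), compound 2 gives 990 nM, which lies within the usual scatter of compound 1 at 710 nM. On these numbers, the two cannot be told apart.

Compound 3 `Clc1ccc(-c2cc(-c3ccoc3)cc(-c3ccccc3Cl)n2)s1` has not yet been measured. It is compound 2 with chloro in place of methyl on an aromatic carbon, so that 2-methylphenyl becomes 2-chlorophenyl (chloro in place of methyl on an aromatic carbon). For the measured compounds named here, no measured pair shows this swap on its own, so the expectation rests on little. Compound 1 at 710 nM differs from compound 2 in several places and still stays within the scatter. A single small swap is therefore expected to produce no step beyond the scatter in this assay, in either direction. The expected change is a 1.1-fold lower number from compound 2 to compound 3 (0.04 log units; within the scatter). For compound 3 the estimated value is 900 nM, with an expected range of 350 nM to 2300 nM.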

Compound 3, half-maximal inhibitory concentration: 1100 nM
Estimate against measurement, compound 3: 1.2-fold (0.09 log units) below, and the stated range covers the measured number.
By their numbers in this assay, from the lowest: compounds 1, 2 and 3 (each within the scatter of the next).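

For the compounds shown here, putting chloro in place of methyl, so that 2-methylphenyl becomes 2-chlorophenyl, is the first swap in this set that can be read on its own, and in this assay it gives a 1.1-fold higher number from compound 2 to compound 3 (0.05 log units; within the scatter) for this single difference. At this place, on an aromatic carbon of a six-membered aromatic ring of carbon only, ortho to a large group, the two groups therefore cannot be told apart on these numbers. Nothing measured alongside these compounds offers an explanation for this result.

Still open, on these data alone, is how this place responds to a group of a different kind, such as an amine or a carboxylic acid, in place of chloro. Also open, as far as these compounds go, is whether a longer chain such as propyl would stay within the scatter here.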